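Phenoxy for cyclohexyl on the core of compound 2

The source may report more compounds than this note shows. Statements on the series, on what has been measured and on what is new or still open speak of the compounds shown alone.

Three compounds of this series have numbers in an ADME assay on HepG2 cells (Homo sapiens) for cytotoxicity, read by luminescence, CellTiter-Glo and ATP content, with a stated time of 72 h; a lower number here means that less compound is needed, a higher number that more compound is needed for the effect. Compound 1 `COc1cccc(CNCCCNc2ccnc3cc(C4CCCCC4)ccc23)c1O` gives 1080 nM, compound 2 `COc1ccc(F)cc1CNCCCNc1ccnc2cc(C3CCCCC3)ccc12` gives 2290 nM and compound 3 `CC(C)(C)c1ccc(-c2ccc3c(NCCCNCc4ccco4)ccnc3c2)cc1` gives 3150 nM. Within the data shown here, compound 2 stands apart from compound 1 by the only single-point step measured so far, a 2.1-fold higher number from compound 1 to compound 2 (0.33 log units; beyond the scatter), while the number of compound 3 falls within the scatter of that of compound 2, so no order between those two can be read.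

Compound 4 `COc1ccc(F)cc1CNCCCNc1ccnc2cc(Oc3ccccc3)ccc12` is not yet measured. It differs from compound 2 in one place: phenoxy in place of cyclohexyl on an aromatic carbon. Among the measured compounds shown here, no measured step touches this part of the core; the step from compound 1 to compound 2 concerns the other end of the molecule, and compound 3 differs from compound 2 in more than one place, so its number shows only where a compound with a different group at this position and a different amine substituent lands. With nothing to weigh the change by, the expectation for compound 4 is a step of no more than the scatter in either direction, a 1.0-fold higher number from compound 2 to compound 4 (0.02 log units; within the scatter). The estimate for compound 4 in this assay is 2400 nM, with a range from 1000 nM to 6000 nM.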

Compound 4, half-maximal effective concentration: 1500 nM
The estimate for compound 4 lay 1.6-fold (0.20 log units) above the measured number; low and high end bracket the measured number.
By their numbers in this assay, from the lowest: compounds 1, 4, 2 and 3 (each within the scatter of the next, the first and the last beyond it).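

In this assay, among these compounds, the first single-point change at this aromatic carbon of the core, phenoxy in place of cyclohexyl, gives a 1.5-fold lower number from compound 2 to compound 4 (0.18 log units; within the scatter). Among the compounds shown here, with the 5-fluoro-2-methoxyphenyl group held constant, replacing a six-membered non-aromatic ring of carbon with phenoxy, which brings one more heavy atom, an oxygen and a hydrogen-bond acceptor, therefore does not produce a difference that this assay can separate from scatter, whereas the step on the amine side, a 2.1-fold higher number from compound 1 to compound 2 (0.33 log units; beyond the scatter), remains the only single-point step beyond it. No measurement at hand bears on why the two groups cannot be told apart here.

As far as these compounds go, this reading rests on one matched pair, so it remains open whether phenoxy and cyclohexyl would also stay within the scatter of each other with the 2-hydroxy-3-methoxyphenyl group of compound 1 on the amine. Also open, from the compounds shown here alone, is how this position responds to groups of another kind, such as an amine, a carboxylic acid or a plain hydrogen in place of the ring-bearing substituents.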